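Swapping the amide-nitrogen aryl group for cyclohexyl

This account rests on a few compounds, and the source may have more. Where it says the series, first, only, none or still open, it means among the compounds named here.

Measured compounds:
compound 1, `COc1cccc(N2C(=O)COc3ccc(-c4cnc(Cl)c(NS(=O)(=O)c5ccc(F)cc5)c4)cc32)c1`, 32700 nM
compound 2, `COc1ccc(N2C(=O)COc3ccc(-c4cnc(OC)c(NS(=O)(=O)c5ccc(F)cc5)c4)cc32)cc1`, 1350 nM

In a functional assay on A549 cells (Homo sapiens) for antiproliferative activity, read by MTT assay, with a stated time of 72 h (a higher number here means a weaker inhibitor, a lower number a stronger inhibitor), compound 2 gives 1350 nM, the lowest of the two numbers, while compound 1 gives 32700 nM, a gap beyond the scatter. Compound 3, `COc1ncc(-c2ccc3c(c2)N(C2CCCCC2)C(=O)CO3)cc1NS(=O)(=O)c1ccc(F)cc1`, differs from compound 2 by cyclohexyl in place of 4-methoxyphenyl on an amide-type nitrogen in a ring. Going by the values given here, no measured pair shows this change, so it is an open question. A modest step toward a higher number, somewhat beyond the scatter, is expected for a 2.2-fold higher number from compound 2 to compound 3 (0.35 log units; beyond the scatter). Compound 3 is estimated at 3000 nM, within a range from 800 nM to 12000 nM.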

Compound 3, half-maximal inhibitory concentration: 24600 nM
For compound 3 the middle estimate is 8.2-fold (0.91 log units) below the measured one; measured number above the stated range.
By their numbers in this assay, from the lowest: compound 2; then compounds 3 and 1 (each within the scatter of the next).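

In this assay, going by these compounds alone, the result gives the only reading of a single change at this amide-type nitrogen in a ring: cyclohexyl in place of 4-methoxyphenyl brings an 18-fold higher number from compound 2 to compound 3 (1.26 log units; beyond the scatter). This position is therefore sensitive to the change, and here the aromatic ring gives the lower number. Nothing given here accounts for this step.

The compounds shown leave open whether the ring or its methoxy group carries the difference, as phenyl at this nitrogen would test. They also leave open how a pyridyl ring or a small methyl group would read there.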